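Notes on the aryl group at the saturated ring carbon

The source may hold more compounds than are shown below. What is called first, only, known or untested is meant among the compounds shown, and "the series" means these compounds.

Compound 3 `CN1C(=O)C(c2ccccc2F)N(C)c2nc(Nc3ccc(S(N)(=O)=O)cc3)ncc21` gives 75 nM in an assay on Sf9 cells for inhibition of serine/threonine-protein kinase 4 (Homo sapiens), read by luminescence and ADP-Glo, with a stated time of 1 h, in the presence of a further agent that is not named here (a lower number here means a stronger inhibitor, a higher number a weaker inhibitor), the lowest number of the three measured; compound 1 `CN1C(=O)C(c2ccccc2)N(C)c2nc(Nc3ccc(S(N)(=O)=O)cc3)ncc21` gives 383 nM and compound 2 `CN1C(=O)C(c2ccc(F)cc2)N(C)c2nc(Nc3ccc(S(N)(=O)=O)cc3)ncc21` gives 1770 nM. The step of a 5.1-fold lower number from compound 1 to compound 3 (0.71 log units; beyond the scatter) and the step of a 24-fold lower number from compound 2 to compound 3 (1.37 log units; beyond the scatter) show that what sits on the saturated ring carbon moves the number well beyond the scatter. Compound 4 `CN1C(=O)C(c2cccs2)N(C)c2nc(Nc3ccc(S(N)(=O)=O)cc3)ncc21` differs from compound 3 by thiophen-2-yl in place of 2-fluorophenyl on a saturated ring carbon. Among the compounds with values here, no measured step holds a thiophen-2-yl, so both steps bear only indirectly: the fluoro that set compound 3 apart from compound 1 leaves, and a five-membered aromatic ring with one hetero atom enters. A higher number is expected, with an estimated step of a 4.0-fold higher number from compound 3 to compound 4 (0.60 log units; beyond the scatter). The estimate for compound 4 is 300 nM, ranging from 80 nM to 1200 nM.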

Compound 4, half-maximal inhibitory concentration: 88 nM
Compound 4: middle estimate off by 3.4-fold (0.53 log units), on the high side; the measured number falls inside the stated range.
By their numbers in this assay, from the lowest: compounds 3 and 4 (each within the scatter of the next); then compound 1; then compound 2.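

In this assay the saturated ring carbon accepts thiophen-2-yl as readily as 2-fluorophenyl, with a 1.2-fold higher number from compound 3 to compound 4 (0.07 log units; within the scatter), so a low number here does not depend on a fluoro or on a six-membered aromatic ring. Thiophen-2-yl also holds the gain over the other aryl groups, with a 4.4-fold lower number from compound 1 to compound 4 (0.64 log units; beyond the scatter) and a 20-fold lower number from compound 2 to compound 4 (1.30 log units; beyond the scatter). No evidence at hand bears on what lies behind these steps.

Still open, going by these compounds, is whether thiophen-3-yl, furan-2-yl or a saturated cyclohexyl group at this carbon would stay level with compound 3 and compound 4.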